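Homologating the aryloxy amide chain toward a pyrrolidinyl amide

This account rests on a few compounds, and the source may have more. Where it says the series, first, only, none or still open, it means among the compounds named here.

The two measured compounds share a core and differ only in the amide-type side chain. Compound 1, `CCCCc1oc2ccccc2c1C(=O)c1ccc(OCC(N)=O)cc1`, sits at a limit in a functional assay on HL-60 cells (Homo sapiens) for antiproliferative activity, read by MTT assay, with a stated time of 24 h (on this read-out higher numbers stand for weaker inhibition and lower numbers for stronger inhibition), giving > 50000 nM. Compound 2, `CCCCNC(=O)COc1ccc(C(=O)c2c(CCCC)oc3ccccc23)cc1`, likewise reaches only a limit in this assay, at > 50000 nM. Within the data shown here, the sole measured step, a step that the two limits leave unreadable from compound 1 to compound 2, is therefore unreadable, and the only evidence is the limit of > 50000 nM in this assay, at which 2 of the 2 values shown sit. Compound 3, `CCCCc1oc2ccccc2c1C(=O)c1ccc(OCCCC(=O)N2CCCC2)cc1`, carries 2-((pyrrolidin-1-yl)carbonyl)ethyl in place of butylcarbamoyl on a saturated chain carbon bound to an oxygen on an aromatic ring. Among the measured compounds shown here, no measured step bears on this change, since both values shown are limits. The expectation for compound 3 is therefore that it remains near the same limit, with the step that the limit leaves unreadable from compound 2 to compound 3 estimated as no clear change beyond the scatter. Compound 3 is accordingly estimated at 60000 nM, within a range from 15000 nM to 200000 nM, with a high chance that this assay again reports only a limit.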

Compound 3, half-maximal inhibitory concentration: 29900 nM
Compound 3: the middle estimate sits 2.0-fold (0.30 log units) above what was measured; low and high end bracket the measured number.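

Among these compounds, compound 3 is the only one of the three compounds that gives a number rather than a limit in this assay, so a change on a saturated chain carbon bound to an oxygen on an aromatic ring can bring a readable value. With 2-((pyrrolidin-1-yl)carbonyl)ethyl at this place, the read-out shows an at least 1.6-fold lower number from compound 2 to compound 3 (0.22 log units; that floor lies within the scatter) against butylcarbamoyl and an at least 1.6-fold lower number from compound 1 to compound 3 (0.22 log units; that floor lies within the scatter) against carbamoyl. The true size of either step stays unknown, as each comparison starts from a limit: the limit of > 50000 nM in this assay, at which 2 of the 3 values shown sit.

The chain length and the pyrrolidine ring change together here, and the compounds shown leave open which of them carries the step. Also open, from the compounds shown here alone, is how a 3-(butylcarbamoyl)propyl chain, a piperidine amide or a free carboxylic acid at the chain end would read.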